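The compounds below may be only part of what the source reports. "The series", "measured", "known", "first", "only" and "open" are said of these compounds alone.

Measured so far:
- compound 1, `CN(C)c1nonc1/C(=N/O)Nc1ccc(F)c(Br)c1`: in an assay on HeLa cells for inhibition of Indoleamine 2,3-dioxygenase 1 (Homo sapiens), with a stated time of 48 h (on this read-out lower numbers stand for stronger inhibition and higher numbers for weaker inhibition), compound 1 gives > 5000 nM, which is a limit of the assay, not a number.
- compound 2, `O/N=C(\Nc1ccc(F)c(Br)c1)c1nonc1NCc1ccccc1`: in this assay compound 2 gives 280 nM.
- compound 3, `NCCNc1nonc1/C(=N/O)Nc1ccc(F)c(Br)c1`: in this assay compound 3 gives 98 nM.

Compound 3 holds the lowest of the two numbers; its nearest neighbour is compound 2, with a 2.9-fold lower number from compound 2 to compound 3 (0.46 log units; beyond the scatter). Compound 4, `CC(=O)NCCNc1nonc1/C(=N/O)Nc1ccc(F)c(Br)c1`, differs from compound 3 by acetyl in place of hydrogen on an amine nitrogen, on an amine nitrogen whose other neighbour is a saturated chain carbon. Every measured step touches this same side chain: an at least 17-fold lower number from compound 1 to compound 2 (1.25 log units; beyond the scatter) and an at least 51-fold lower number from compound 1 to compound 3 (1.70 log units; beyond the scatter), both large, and the modest 2.9-fold lower number from compound 2 to compound 3 (0.46 log units; beyond the scatter). The acetyl group enters where the free amine of compound 3 stands, so the change sits on the group that separates compound 3 from compound 2. A modest weakening in this assay is expected, in the direction of compound 2, not a large one. For compound 4 the estimate is 250 nM, within 80 nM to 800 nM, that is a 2.6-fold higher number from compound 3 to compound 4 (0.41 log units; beyond the scatter).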

Compound 4, half-maximal inhibitory concentration: 17 nM
For compound 4 the middle estimate is 15-fold (1.17 log units) above the measured one, and the stated range ends above it.
By their numbers in this assay, from the lowest: compound 4; then compound 3; then compound 2. At a limit, above all of these: compound 1.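

Putting acetyl on the amine nitrogen of the 2-aminoethyl group strengthens inhibition in this assay instead of weakening it, with a 5.8-fold lower number from compound 3 to compound 4 (0.76 log units; beyond the scatter), so a free amine on this chain is not required for a low number among these compounds. Compound 4 now holds the lowest number of the four, with a 16-fold lower number from compound 2 to compound 4 (1.22 log units; beyond the scatter) and an at least 290-fold lower number from compound 1 to compound 4 (2.46 log units; beyond the scatter). The value of compound 1 is a limit of the assay, not a number: the limit of > 5000 nM in this assay, at which 1 of the 4 values shown sits.

The compounds shown carry only one acyl group at one chain length, so it remains open whether the gain belongs to acetyl itself. How a sulfonamide, a urea or a longer chain ending in the acetamido group would compare at this position also stays unanswered.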